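A few compounds are considered here, and "the series" means these few. Any claim that something is new, unique, unknown or untested is made for them only; others in the source may bear on it.

Compound 1 `Cc1ccc(C(=O)NC(=S)NNc2ncnc3ccccc23)cc1` gives 3760 nM in a functional assay on MGC-803 cells (Homo sapiens) for cytotoxicity, read by MTT assay, with a stated time of 72 h; a lower number here means a stronger inhibitor, a higher number a weaker inhibitor.
Compound 2 `COc1ccccc1C(=O)NC(=S)NNc1ncnc2ccccc12` gives 14300 nM in this assay.
Compound 3 `O=C(NC(=S)NNc1ncnc2ccccc12)c1ccc(F)cc1` gives 3600 nM in this assay.

Compound 3 holds the lowest of the three numbers, yet the gap to compound 1 is within the scatter; only compound 2 stands apart, the step being a 4.0-fold lower number from compound 2 to compound 3 (0.60 log units; beyond the scatter). Compound 4 `O=C(NC(=S)NNc1ncnc2ccccc12)c1ccccc1` differs from compound 3 by hydrogen in place of fluoro on an aromatic carbon. For the measured compounds named here, the one measured step that bears on this is the earlier swap at the same aromatic carbon, a 1.0-fold lower number from compound 1 to compound 3 (0.02 log units; within the scatter), which stayed within the scatter. A step of similar size is therefore expected here, a 1.3-fold higher number from compound 3 to compound 4 (0.10 log units; within the scatter), with no direction beyond the scatter. Compound 4 is estimated at 4500 nM, within 2000 nM to 10000 nM.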

Compound 4, half-maximal inhibitory concentration: 6990 nM
The estimate for compound 4 lay 1.6-fold (0.19 log units) below the measured number; the range from low to high includes it.
By their numbers in this assay, from the lowest: compounds 3, 1 and 4 (each within the scatter of the next); then compound 2.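

In this assay, hydrogen in place of fluoro gives a 1.9-fold higher number from compound 3 to compound 4 (0.29 log units; within the scatter) and hydrogen in place of methyl gives a 1.9-fold higher number from compound 1 to compound 4 (0.27 log units; within the scatter), so on this aromatic carbon, para to a large group, the plain phenyl compound is not separated from either substituted one. Only a 2.0-fold lower number from compound 2 to compound 4 (0.31 log units; beyond the scatter) lies beyond the scatter, which leaves compound 2 apart from the plain phenyl compound as well. No measurement shown explains these numbers.

Open, as far as these compounds go, is whether an amine or a carboxylic acid on this carbon would stay within the scatter of compound 1, compound 3 and compound 4. Also open, from the compounds shown here alone, is whether 4-methoxyphenyl would give a number like that of 2-methoxyphenyl.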